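Chloro in place of amino on the shared core

The source may report more compounds than this note shows. Statements on the series, on what has been measured and on what is new or still open speak of the compounds shown alone.

Of the compounds shown here, three that carry the amino group have numbers so far in a functional assay on CEM-SS cells (Homo sapiens) for cytotoxicity (on this read-out lower numbers stand for stronger inhibition and higher numbers for weaker inhibition), and all sit at one level. Compound 1 (`Nc1nc2cc(Cl)c(Cl)cc2n1Cc1ccc(Cl)c(Cl)c1`) gives 30000 nM and compound 2 (`Nc1nc2cc(Cl)c(Cl)cc2n1Cc1cccc(C(F)(F)F)c1`) gives 34000 nM on this measure. Compound 3 (`Nc1nc2cc(Cl)c(Cl)cc2n1Cc1ccccc1Cl`) stands at 36000 nM and lies within the scatter of both compound 2 and compound 1, so no order can be drawn among the three.

Compound 4 (`Clc1cc2nc(Cl)n(Cc3ccccc3Cl)c2cc1Cl`) differs from compound 3 by chloro in place of amino on an aromatic carbon, on the five-membered aromatic ring with 2 nitrogen, between two ring nitrogen atoms. Within the data shown here, all measured compounds keep the amino group, and no measured pair shows what this exchange does. The expectation therefore starts from compound 3 at 36000 nM and allows a wide range on both sides.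

In this assay no step beyond the scatter is expected, with a slight lean toward weaker inhibition, and a 1.3-fold higher number from compound 3 to compound 4 (0.10 log units; within the scatter) is the estimated step. For compound 4 the estimated value is 45000 nM with an expected range from 14000 nM to 100000 nM in this measurement.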

Compound 4, half-maximal inhibitory concentration: 70000 nM
For compound 4 the middle estimate is 1.6-fold (0.19 log units) below the measured one; the range from low to high includes it.
By their numbers in this assay, from the lowest: compounds 1, 2, 3 and 4 (each within the scatter of the next, the first and the last beyond it).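

In this assay, among these compounds, the first measured exchange at this position gives a 1.9-fold higher number from compound 3 to compound 4 (0.29 log units; within the scatter) and so stays inside the usual spread of repeat measurements, although only just. On this single pair, therefore, the amino group on the aromatic carbon between two ring nitrogen atoms is not shown to be required for the level of this read-out, even though chloro brings neither the hydrogen-bond donor nor the hydrogen-bond acceptor counted for amino. No independent measurement accompanies this pair that could account for the size of the step.

Whether a methyl group, a hydroxyl group or a longer amine at the same position would stay at this level remains open, as the amino and chloro pair is the only exchange shown there. From the compounds shown here alone, it is also open whether chloro in place of amino gives a comparable step on the compounds that carry the other substituents of compound 1 and compound 2, since this exchange is read on the substituent of compound 3 alone.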